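Working notes: amine methyl removal, compound 1 to compound 4

The compounds below may be only part of what the source reports. "The series", "measured", "known", "first", "only" and "open" are said of these compounds alone.

Measured in an assay on isolated protein for inhibition of DNA topoisomerase 1 (Homo sapiens), with a stated time of 15 min; a higher number here means a weaker inhibitor, a lower number a stronger inhibitor:
- compound 1 `CN[C@@H]1CCN(c2cc3c(cc2F)c(=O)c(C(=O)O)cn3Cc2ccc(-c3ccccc3)cc2)C1`: 34800 nM
- compound 2 `COc1c(NCCN)c(F)cc2c(=O)c(C(=O)O)cn(Cc3ccc(-c4ccccc4)cc3)c12`: > 200000 nM
- compound 3 `COc1c(N2CC[C@@H](CN)C2)c(F)cc2c(=O)c(C(=O)O)cn(Cc3ccc(-c4ccc(F)cc4)cc3)c12`: 60900 nM

Compound 1 has the lowest of the two numbers obtained in this assay. Its nearest neighbour is compound 3, whose value lies within the scatter of compound 1, so no order between the two can be claimed. For compound 2 the result is only a limit of this assay, not a number (the limit of > 200000 nM in this assay, at which 1 of the 3 values shown sits).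

Compound 4 `N[C@@H]1CCN(c2cc3c(cc2F)c(=O)c(C(=O)O)cn3Cc2ccc(-c3ccccc3)cc2)C1` is not yet measured. It differs from compound 1 in one place: hydrogen in place of methyl on an amine nitrogen. Among the measured compounds shown here, no pair of measured compounds here differs in a single place, so no measured step is available to set the size of this change. The change is small in what it removes, and nothing among compounds 1, 2 and 3 speaks for a shift beyond the scatter.

For compound 4 in this assay the expected step is a 1.1-fold higher number from compound 1 to compound 4 (0.06 log units; within the scatter), estimated as no change beyond the scatter. Compound 4 is therefore expected to give 40000 nM, with a likely range from 12000 nM to 130000 nM.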

Compound 4, half-maximal inhibitory concentration: 63600 nM
The estimate for compound 4 lay 1.6-fold (0.20 log units) below the measured number; low and high end bracket the measured number.
By their numbers in this assay, from the lowest: compounds 1, 3 and 4 (each within the scatter of the next). At a limit, above all of these: compound 2.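

The pair gives the series its first measured single-place step in this assay: hydrogen in place of methyl on an amine nitrogen gives a 1.8-fold higher number from compound 1 to compound 4 (0.26 log units; within the scatter). At this position, 3-(methylamino)pyrrolidin-1-yl and 3-aminopyrrolidin-1-yl therefore cannot be told apart in this assay, and the methyl can be removed without a readable shift in the number. No measured property in the data at hand bears on this step, and its origin remains unassigned.

On these data alone, the step rests on a single pair, while compound 2 and compound 3 each differ from compound 1 in more than one place, so it remains open whether the same exchange would stay within the scatter on another core. Also open is how this assay would respond to a larger group on the same amine nitrogen, such as an ethyl or an acetyl, or to a second methyl there, since the compounds shown cover only hydrogen and a single methyl at this nitrogen.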